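This account rests on a few compounds, and the source may have more. Where it says the series, first, only, none or still open, it means among the compounds named here.

Three compounds share one core and differ only in the group attached to one aromatic carbon. Compound 1 `O=C(CCc1ccc(-c2cccc(F)c2)cc1)N1CCCC1` carries a 3-fluorophenyl there, and in an assay on HEK293 cells for inhibition of N-acylethanolamine-hydrolyzing acid amidase (Rattus norvegicus), read by LC-MS, with a stated time of 30 min (a lower number here means a stronger inhibitor, a higher number a weaker inhibitor), compound 1 gives 1800 nM. Compound 2 `O=C(CCc1ccc(-c2ccccn2)cc1)N1CCCC1` carries a pyridin-2-yl instead. In this assay compound 2 reaches only the limit of > 100000 nM, which is not a number but the edge of what the assay reports. Compound 3 `O=C(CCc1ccc(-c2cccs2)cc1)N1CCCC1` carries a thiophen-2-yl. In this assay compound 3 likewise stops at the limit of > 100000 nM. So compound 3 stands at the weak end of what has been measured, sharing the limit of > 100000 nM in this assay, at which 2 of the 3 values shown sit, with compound 2, and the step that the two limits leave unreadable from compound 2 to compound 3 cannot be read. The two readable steps are large: an at least 55-fold higher number from compound 1 to compound 2 (1.74 log units; beyond the scatter) and an at least 55-fold higher number from compound 1 to compound 3 (1.74 log units; beyond the scatter).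

The next compound, compound 4 `O=C(CCc1ccc(C2CCCCC2)cc1)N1CCCC1`, is made from compound 3 by cyclohexyl in place of thiophen-2-yl on an aromatic carbon. Going by the values given here, no measured step matches an exchange of an aromatic ring for a non-aromatic one, so the expectation leans on compound 1, whose 3-fluorophenyl gave a readable number, and on compound 3 at its limit. The expected outcome is a step of an at least 16-fold lower number from compound 3 to compound 4 (1.22 log units; beyond the scatter), a move back toward a measurable number without confidence about how far. The estimate for compound 4 in this assay is therefore 6000 nM, within a range from 1000 nM to 100000 nM.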

Compound 4, half-maximal inhibitory concentration: 500 nM
Compound 4: the middle estimate sits 12-fold (1.08 log units) above what was measured; measured number outside the range, below it.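

In this assay, the position para to a group of 9 heavy atoms turns out not to need an aromatic ring: compound 4, with its six-membered non-aromatic ring of carbon only, is the strongest inhibitor of the four, with a 3.6-fold lower number from compound 1 to compound 4 (0.56 log units; beyond the scatter). The same exchange gives an at least 200-fold lower number from compound 3 to compound 4 (2.30 log units; beyond the scatter) and an at least 200-fold lower number from compound 2 to compound 4 (2.30 log units; beyond the scatter), so among these four compounds the two groups with a ring of carbon only give readable numbers, while the two with a hetero atom in the ring do not, and no compound shown goes against this. That split cannot separate the hetero atom from the other differences between these groups, and the step between compound 2 and compound 3 cannot be read, since both stop at a limit: the limit of > 100000 nM in this assay, at which 2 of the 4 values shown sit.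

The compounds shown leave open whether the gain of compound 4 comes from losing aromaticity, since a plain phenyl, without the fluorine of compound 1, is not among them. They also leave open how much change this position tolerates, for example a smaller cyclopentyl, or a piperidine ring that brings an amine into the cyclohexyl's place.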